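Trimming Isopropyl to Methyl on the Phenyl of Compound 2

This account rests on a few compounds, and the source may have more. Where it says the series, first, only, none or still open, it means among the compounds named here.

Compound 2 `Cc1ccc(Nc2nc(SCc3cn(Cc4ccccc4Cl)nn3)nc(-c3ccc(C(C)C)cc3)c2C#N)cc1` is tested in a functional assay on MGC-803 cells (Homo sapiens) for inhibition, read by MTT assay, with a stated time of 72 h (on this read-out higher numbers stand for weaker inhibition and lower numbers for stronger inhibition), and returns only the limit > 64000 nM. Compound 3 `COc1ccc(Nc2nc(SCc3cn(Cc4ccccc4Cl)nn3)nc(-c3ccc(C(C)C)cc3)c2C#N)cc1` likewise gives only the limit > 64000 nM. Compound 1 `Cc1ccc(Nc2nc(SCc3cn(Cc4ccccc4Cl)nn3)nc(-c3ccccc3)c2C#N)cc1` gives a number, 7190 nM, so that an at least 8.9-fold higher number from compound 1 to compound 2 (0.94 log units; beyond the scatter) is a readable loss, whereas a step that the two limits leave unreadable from compound 2 to compound 3 cannot be sized. Compound 4 `Cc1ccc(Nc2nc(SCc3cn(Cc4ccccc4Cl)nn3)nc(-c3ccc(C)cc3)c2C#N)cc1` carries methyl in place of isopropyl on an aromatic carbon, which undoes part of the change that separates compound 1 from compound 2. Because an at least 8.9-fold higher number from compound 1 to compound 2 (0.94 log units; beyond the scatter) rose when isopropyl replaced hydrogen, the smaller methyl is expected to sit between those two results. Compound 4 is therefore expected to show a downward step of an at least 3.2-fold lower number from compound 2 to compound 4 (0.50 log units; beyond the scatter). Compound 4 is estimated at 20000 nM, with a range from 6000 nM to 64000 nM.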

Compound 4, half-maximal inhibitory concentration: 24400 nM
Beside the measured number, compound 4's estimate is 1.2-fold (0.09 log units) below it, and the stated range covers the measured number.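

In this assay, methyl in place of hydrogen already gives a 3.4-fold higher number from compound 1 to compound 4 (0.53 log units; beyond the scatter), so a group at this position need not be as large as isopropyl for the number to rise. Methyl in place of isopropyl gives an at least 2.6-fold lower number from compound 2 to compound 4 (0.41 log units; beyond the scatter), and compounds 1, 4 and 2 therefore rise in order from hydrogen through methyl to isopropyl. The top of that order remains a bound and not a size: the limit of > 64000 nM in this assay, at which 2 of the 4 values shown sit.

The compounds shown leave open how a hydroxyl, a fluorine or an amine at this position would read, and whether any group there can match hydrogen.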